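The source may report more compounds than this note shows. Statements on the series, on what has been measured and on what is new or still open speak of the compounds shown alone.

Compound 1 `O=C(Nc1cccc(-n2cc(-c3ccncc3)c(-c3cc(O)cc(Cl)c3)n2)c1)Nc1ccc(Cl)c(Cl)c1` gives 97%.
Compound 2 `COc1cc(Cl)cc(-c2nn(-c3cccc(NC(=O)Nc4ccc(Cl)c(Cl)c4)c3)cc2-c2ccncc2)c1` gives 91%.

Both numbers come from a functional assay on HT-29 cells (Homo sapiens) for inhibition, read by sulforhodamine B assay, with a stated time of 48 h, tested at 0.1 uM; a lower number here means a stronger effect, a higher number a weaker effect of the compound at the concentration tested. Within the data shown here, compound 2 stands at the lowest of the two values, but its only neighbour is compound 1, and the one measured step, a number 6 percentage points lower from compound 1 to compound 2 (within the scatter), lies within the scatter, so the two compounds cannot be told apart on these data.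

Compound 3 `COc1cc(Cl)cc(-c2nn(-c3cccc(NC(=O)c4cccc(C(F)(F)F)c4)c3)cc2-c2ccncc2)c1` is the unmeasured compound. It keeps the core and the methoxy group of compound 2 and differs at the carbonyl carbon: 3-(trifluoromethyl)phenyl in place of (3,4-dichlorophenyl)amino on a carbonyl carbon. The urea of compound 2 thus becomes an amide, and the aromatic ring carried on that carbonyl changes as well.

Among the measured compounds shown here, no measured step touches this part of the molecule; the single step from compound 1 to compound 2 concerns the oxygen on the other aromatic ring and was itself within the scatter. There is therefore nothing in the data to point to a change in either direction, and the expectation is no step beyond the scatter.

Compound 3 is estimated to give 90% in this assay, with a range from 72% to 102%. The expected step is a number 1 percentage points lower from compound 2 to compound 3 (within the scatter).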

Compound 3, a percentage reported as activity, at one concentration (the size of the read-out at that concentration, not a potency): 93%
Compound 3: middle estimate off by 3 percentage points, on the low side; the measured number falls inside the stated range.
By their numbers in this assay, from the lowest: compounds 2, 3 and 1 (each within the scatter of the next).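

In this assay, the change on the carbonyl carbon gives a number 2 percentage points higher from compound 2 to compound 3 (within the scatter), so this replacement at the end of the molecule far from the methoxy group leaves the read-out indistinguishable from that of the urea. Among these compounds, the earlier step touched only the oxygen on the other aromatic ring, so this is the first view of this position, and it shows that the urea nitrogen with its hydrogen-bond donor and the two chlorine atoms can be exchanged for a trifluoromethyl-bearing ring with no change beyond the scatter at this one concentration. No measurement shown here offers an explanation for this result.

On these data alone, the step alters both the link and the ring at once, so the effect of each alone stays unknown; a (3-(trifluoromethyl)phenyl)amino group on the carbonyl carbon would separate the two. As far as these compounds go, whether the position responds to something quite different, such as a short alkyl chain, an amine or a carboxylic acid in place of the aromatic ring, also stays open, as does any difference between these compounds at other concentrations.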